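Second chloro on compound 2: working notes

The source may report more compounds than this note shows. Statements on the series, on what has been measured and on what is new or still open speak of the compounds shown alone.

In a functional assay on Jurkat cells (Homo sapiens) for antiproliferative activity, read by MTT assay, with a stated time of 72 h (a higher number here means a weaker inhibitor, a lower number a stronger inhibitor), three compounds have been measured so far. Compound 1 (`COc1cc(-c2ncnn2-c2ccc(Cl)cc2Cl)cc(OC)c1OC`) gives > 10000 nM as a limit of the assay, not a number. Compound 2 (`COc1cc(-n2ncnc2-c2ccc(Cl)cc2)cc(OC)c1OC`) gives > 10000 nM as a limit too. Compound 3 (`COc1cc(-n2ncnc2-c2ccc(OC(F)(F)F)cc2)cc(OC)c1OC`) gives > 10000 nM as a limit as well. The series stands at the limit of > 10000 nM in this assay, at which 3 of the 3 values shown sit, and compound 2 has no number of its own to start from.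

Compound 4 (`COc1cc(-n2ncnc2-c2ccc(Cl)c(Cl)c2)cc(OC)c1OC`) differs from compound 2 by chloro in place of hydrogen on an aromatic carbon in one place: chloro in place of hydrogen on an aromatic carbon, ortho to a chloro group, so that 4-chlorophenyl becomes 3,4-dichlorophenyl. Within the data shown here, the one measured step that bears on this is a step that the two limits leave unreadable from compound 2 to compound 3 and it has no readable size. No step beyond the scatter is therefore expected in this assay and no direction can be given. Expected here is a number no higher from compound 2 to compound 4 (the limit leaves the size open) and nothing larger. For compound 4 the estimated value is 10000 nM with an expected range from 4000 nM to 20000 nM and a limit as the likeliest report.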

Compound 4, half-maximal inhibitory concentration: > 10000 nM
Compound 4: no number, only a limit (the forecaster's own chance of this, stated with the estimate: 85%); the middle value lies on the limit itself.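

No step can be read from compound 2 to compound 4 in this assay: each gives only a limit of the assay, not a number. The compounds shown leave open how far any of the four lies past that limit, and whether any change on the shared core would give a measurable value.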